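A few compounds are considered here, and "the series" means these few. Any claim that something is new, unique, unknown or untested is made for them only; others in the source may bear on it.

Measured compounds:
- compound 1 `O=C(O[C@H]1C[C@H](n2cc(F)c(=O)[nH]c2=O)O[C@@H]1COP(=O)(O)Oc1ccccc1)c1ccccc1`: 5860 nM
- compound 2 `CCCCCCCCCc1ccc(OP(=O)(O)OC[C@H]2O[C@@H](n3cc(F)c(=O)[nH]c3=O)C[C@@H]2OC(=O)c2ccccc2)cc1`: 40100 nM
- compound 3 `C[N+]1(C)CCC(OP(=O)([O-])OC[C@H]2O[C@@H](n3cc(F)c(=O)[nH]c3=O)C[C@@H]2OC(=O)c2ccccc2)CC1`: 27200 nM

In a functional assay on HeLa cells (Homo sapiens) for cytotoxicity, read by MTT assay, with a stated time of 48 h (a lower number here means a stronger inhibitor, a higher number a weaker inhibitor), compound 1 gives the lowest of the three numbers. The step of a 6.8-fold higher number from compound 1 to compound 2 (0.84 log units; beyond the scatter) and the step of a 4.6-fold higher number from compound 1 to compound 3 (0.67 log units; beyond the scatter) both move away from compound 1 to higher numbers, each by a modest amount beyond the scatter.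

Compound 4 `O=c1[nH]c(=O)n([C@H]2C[C@H](O)[C@@H](COP(=O)(O)Oc3ccccc3)O2)cc1F` differs from compound 1 in one place: hydrogen in place of benzoyl on an oxygen on a saturated carbon. Neither measured step touches this oxygen; both alter the group attached to the phosphate on the other side of the shared core. So no measured step bears directly on this change, and the only guide is that the two changes made from compound 1 so far each raised the number modestly in this assay.

On that weak basis, a step from compound 1 to compound 4 of roughly a 1.9-fold higher number from compound 1 to compound 4 (0.27 log units; within the scatter) is expected, with a wide range that also allows a step within the scatter. For compound 4 the estimate in this assay is 11000 nM, expected to fall between 3500 nM and 40000 nM.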

Compound 4, half-maximal inhibitory concentration: 15200 nM
Compound 4: middle estimate off by 1.4-fold (0.14 log units), on the low side, within the range that was stated.
By their numbers in this assay, from the lowest: compound 1; then compounds 4, 3 and 2 (each within the scatter of the next, the first and the last beyond it).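

The earlier compounds shown here changed only the group on the phosphate, so they said nothing about the oxygen on a saturated carbon that carries the benzoyl group. Compound 4 shows that this site also matters: in this assay the change from benzoyloxy to hydroxy gives a 2.6-fold higher number from compound 1 to compound 4 (0.41 log units; beyond the scatter) and so goes beyond the usual scatter, with the benzoyl form giving the lower number of this pair. No evidence is available to explain this step.

Still open, from the compounds shown here alone, is how a smaller acetyl group, a longer acyl chain or an ester carrying an amine on this oxygen would read in this assay compared with benzoyl. Also open, going by these compounds, is whether replacing benzoyl with hydrogen would move the number in the same direction in compound 2 and compound 3, which carry other groups on the phosphate.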